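Swapping Ethynyl for Iodo on Two Related Cores

This account rests on a few compounds, and the source may have more. Where it says the series, first, only, none or still open, it means among the compounds named here.

Compound 1 `C#Cc1cn([C@@H]2O[C@H](CO)[C@@H](O)[C@H]2O)c2nc(C)nc(N)c12`: > 20000 nM
Compound 2 `Cc1nc(N)c2c(I)cn([C@@H]3O[C@H](CO)[C@@H](O)[C@H]3O)c2n1`: 9030 nM
Compound 3 `C#Cc1cn([C@@H]2O[C@H](CO)[C@@H](O)[C@H]2O)c2ncnc(OC)c12`: > 20000 nM

In a functional assay on CCRF-CEM cells (Homo sapiens), read by MTT assay, with a stated time of 72 h (a higher number here means a weaker inhibitor, a lower number a stronger inhibitor), compound 1 reaches only a limit, > 20000 nM. Compound 2 gives 9030 nM in this assay. The change iodo in place of ethynyl on an aromatic carbon thus brought an at least 2.2-fold lower number from compound 1 to compound 2 (0.34 log units; beyond the scatter). Compound 3 likewise returns a limit in this assay, > 20000 nM, and the limit of > 20000 nM in this assay, at which 2 of the 3 values shown sit, shows how many of the values sit there. How the core of compound 3 differs from that of compound 1 is not broken down here. Compound 4 `COc1ncnc2c1c(I)cn2[C@@H]1O[C@H](CO)[C@@H](O)[C@H]1O` is not yet measured; it carries the same change as compound 2, (iodo in place of ethynyl on an aromatic carbon), with the surroundings of the place described in identical words. Compound 4 is expected to show an at least 1.6-fold lower number from compound 3 to compound 4 (0.22 log units; that floor lies within the scatter) in this assay, resting on the measured step of an at least 2.2-fold lower number from compound 1 to compound 2 (0.34 log units; beyond the scatter) from a starting point that is also a limit. Compound 4 is therefore estimated at 12000 nM, between 4000 nM and 40000 nM.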

Compound 4, half-maximal inhibitory concentration: 1150 nM
Compound 4: the middle estimate sits 10-fold (1.02 log units) above what was measured; measured number below the stated range.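

In this assay, iodo in place of ethynyl on an aromatic carbon gave an at least 17-fold lower number from compound 3 to compound 4 (1.24 log units; beyond the scatter), so the number fell on the core of compound 3 as it did on the core of compound 1. The change thus carries over in direction between these two cores, but its size cannot be compared between them: the same change on two cores in this assay, an at least 2.2-fold lower number (0.34 log units; beyond the scatter) from compound 1 to compound 2 and an at least 17-fold lower number (1.24 log units; beyond the scatter) from compound 3 to compound 4; the limit leaves it open whether they differ The pairs cover only these two cores and set no rule for any other core.

The compounds shown leave open how bromo, a nitrile or an amine would read in this assay at this same place on either core. They also leave open whether a longer chain there would follow iodo or ethynyl.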